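This account rests on a few compounds, and the source may have more. Where it says the series, first, only, none or still open, it means among the compounds named here.

Measured in a functional assay on HCC 2998 cells (Homo sapiens) for antiproliferative activity; on this read-out higher numbers stand for weaker inhibition of growth and lower numbers for stronger inhibition of growth:
- compound 1 `COc1ccc(-c2nc3cc(F)ccc3s2)cc1C`: 540 nM
- compound 2 `COc1ccc(-c2nc3cc(F)ccc3s2)cc1F`: 13700 nM

Compound 2 carries the higher of the two numbers, so it is the weaker growth inhibitor of the pair. The gap is a 25-fold higher number from compound 1 to compound 2 (1.40 log units; beyond the scatter), and it came with fluoro in place of methyl on an aromatic carbon. Compound 3 `COc1ccc(-c2nc3cc(F)ccc3s2)cc1Cl` differs from compound 2 by chloro in place of fluoro on an aromatic carbon, with chloro in place of fluoro at the same aromatic carbon, ortho to a methoxy group. Within the data shown here, the single measured step is the only guide, and no chloro compound has been measured yet. A sizeable move toward lower numbers in this assay is expected. Compound 1 gives 540 nM and will probably still hold the lower number. The expected step is a 9.1-fold lower number from compound 2 to compound 3 (0.96 log units; beyond the scatter). For compound 3 the estimate is 1500 nM, with an expected range of 350 nM to 6000 nM.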

Compound 3, concentration for 50% growth inhibition: 2500 nM
The estimate for compound 3 lay 1.7-fold (0.22 log units) below the measured number; the range from low to high includes it.
By their numbers in this assay, from the lowest: compound 1; then compound 3; then compound 2.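

At the aromatic carbon ortho to a methoxy group, the change between two halogens is itself readable in this assay: there is a 5.5-fold lower number from compound 2 to compound 3 (0.74 log units; beyond the scatter), so fluoro is not the only substituent here that gives a high number. Chloro still falls short of methyl, with a 4.6-fold higher number from compound 1 to compound 3 (0.67 log units; beyond the scatter), which puts the three compounds in the order methyl, chloro, fluoro, from lowest number to highest. No data at hand explain this order.

The compounds shown leave open whether ethyl, trifluoromethyl, a nitrile or an amine at this carbon would give a lower number than the methyl of compound 1. They also leave open whether the same order would hold with the methoxy group replaced by a hydroxyl group.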